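A few compounds are considered here, and "the series" means these few. Any claim that something is new, unique, unknown or untested is made for them only; others in the source may bear on it.

Working notes on the series. Three analogues sharing one core have been run in a functional assay on MGC-803 cells (Homo sapiens) for inhibition, read by MTT assay, with a stated time of 72 h; on this read-out higher numbers stand for weaker inhibition and lower numbers for stronger inhibition. Compound 1 `C#CCSc1nc(Nc2ccc(C)cc2)c2ccncc2n1` gives 8090 nM, compound 2 `C#CCSc1nc(Nc2ccccc2Cl)c2ccncc2n1` gives 27600 nM, and compound 3 `C#CCSc1nc(Nc2cccc(Cl)c2)c2ccncc2n1` gives 2190 nM. Compound 2 stands at the highest number of the three: the move from compound 1 to compound 2 is a 3.4-fold higher number from compound 1 to compound 2 (0.53 log units; beyond the scatter), and the move from compound 2 to compound 3 is a 13-fold lower number from compound 2 to compound 3 (1.10 log units; beyond the scatter), so the 2-chlorophenyl analogue is the weakest inhibitor in this assay.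

Compound 4 `C#CCSc1nc(Nc2ccc(Cl)cc2Cl)c2ccncc2n1` is not yet measured. Relative to compound 2 the change is chloro in place of hydrogen on an aromatic carbon, leaving the existing chloro group in place. Among the measured compounds shown here, no measured step adds a second substituent to the pendant phenyl; the measured steps only relocate a single group. Those that bear on it are the modest step of a 3.4-fold higher number from compound 1 to compound 2 (0.53 log units; beyond the scatter) and the large step of a 13-fold lower number from compound 2 to compound 3 (1.10 log units; beyond the scatter), both showing that the 2-chlorophenyl pattern sits at the weak end, and the modest step of a 3.7-fold lower number from compound 1 to compound 3 (0.57 log units; beyond the scatter). Since compound 2 is the starting point, a further chloro is expected to give a modest step toward lower numbers, a 2.8-fold lower number from compound 2 to compound 4 (0.44 log units; beyond the scatter), without reaching compound 3. Compound 4 is therefore estimated at 10000 nM in this assay, within a range of 3000 nM to 30000 nM.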

Compound 4, half-maximal inhibitory concentration: 25500 nM
Compound 4: middle estimate off by 2.6-fold (0.41 log units), on the low side; the measured number falls inside the stated range.
By their numbers in this assay, from the lowest: compound 3; then compound 1; then compounds 4 and 2 (each within the scatter of the next).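

In this assay chloro in place of hydrogen, on the aromatic carbon para to a large group and meta to a chloro group, gives a 1.1-fold lower number from compound 2 to compound 4 (0.03 log units; within the scatter) and leaves compound 2 and compound 4 indistinguishable on this read-out. Among the compounds shown here, this is the first step that adds a substituent to the pendant phenyl instead of relocating one, and with the existing chloro group in place, this second chloro shifts the number by no more than the scatter. No supporting measurement bears on why this step is flat.

The compounds shown leave open whether chloro at this carbon would also give a step within the scatter without the existing chloro group, since only the 2-chlorophenyl background is covered here. They also leave open whether a different group at the same carbon, such as methoxy, an amine or a carboxylic acid, would give a step beyond the scatter, or whether this carbon tolerates substitution generally.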